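Swapping the Ester Group: What to Expect for Compound 4

The compounds below may be only part of what the source reports. "The series", "measured", "known", "first", "only" and "open" are said of these compounds alone.

compound 1, `CCOC(=O)c1c(-c2cccc(OC)c2)csc1N`: 82%
compound 2, `CCOC(=O)c1c(-c2cccc(C(F)(F)F)c2)csc1N`: 30%
compound 3, `CCOC(=O)c1c(-c2cccc(C#N)c2)csc1N`: 32%

In an assay on isolated protein for inhibition of protein kinase C zeta type (Homo sapiens), with stated times of 1 h and 2.5 min, tested at 30 uM (on this read-out lower numbers stand for less inhibition and higher numbers for more inhibition at the one concentration tested (going by the name of the read-out)), compound 3 gives 32%, the second highest of the three numbers. It sits close to compound 2, which gives 30%, and the gap a number 2 percentage points higher from compound 2 to compound 3 (within the scatter) is within the scatter. It lies well below compound 1, which gives 82%.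

Compound 4, `N#Cc1cccc(-c2csc(N)c2C(=O)OCc2ccccc2)c1`, differs from compound 3 by phenyl in place of methyl on a saturated chain carbon bound to an oxygen next to a carbonyl group. Among the measured compounds shown here, none of the measured steps touches this place: a number 52 percentage points lower from compound 1 to compound 2 (beyond the scatter) and a number 50 percentage points lower from compound 1 to compound 3 (beyond the scatter) were both large, but both concern the group on the aromatic ring. On these data alone, the ester change itself is untested, so the expectation rests on compound 3 alone. The step from compound 3 to compound 4 is therefore expected to be small, a number 3 percentage points higher from compound 3 to compound 4 (within the scatter), with wide uncertainty. Compound 4 is estimated at 35%, in a range from 10% to 60%.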

Compound 4, a percentage reported as inhibition, at one concentration (the size of the read-out at that concentration, not a potency): 25%
For compound 4 the middle estimate is 10 percentage points above the measured one, within the range that was stated.
By their numbers in this assay, from the lowest: compounds 4, 2 and 3 (each within the scatter of the next); then compound 1.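

Phenyl in place of methyl on this saturated chain carbon, which turns the ethyl ester into a benzyl ester and adds a six-membered aromatic ring, gives a number 7 percentage points lower from compound 3 to compound 4 (within the scatter) in this assay. With the cyano group on the aromatic ring, this much larger ester group therefore leaves the read-out unchanged within the scatter. Nothing available explains this result.

On these data alone, whether a benzyl ester would behave the same way alongside the methoxy group of compound 1 stays open. So does the effect of a carboxylic acid or an amide in place of the ester.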